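Compound 3 to compound 4: a 3-acetylphenyl exchange

The source may report more compounds than this note shows. Statements on the series, on what has been measured and on what is new or still open speak of the compounds shown alone.

Measured so far in an ADME assay on HepG2 cells (Homo sapiens) for cytotoxicity; a higher number here means that more compound is tolerated, a lower number that less compound is tolerated:
Compound 1 `CSc1cccc(N2C(=O)CN(c3cccc(C(F)(F)F)c3)CC2C(=O)NC2CCCC2)c1` – 20000 nM
Compound 2 `COc1cccc(N2CC(=O)N(c3cccc(SC)c3)C(C(=O)NC3CCCC3)C2)c1` – > 50000 nM (a limit of the assay, not a number)
Compound 3 `CSc1cncc(N2C(=O)CN(c3cccc(C(F)(F)F)c3)CC2C(=O)NC2CCCC2)c1` – 26000 nM

For the measured compounds named here, compound 3 holds one of only two actual numbers in this small set. The step of a 1.3-fold higher number from compound 1 to compound 3 (0.11 log units; within the scatter) keeps those two numbers together, and the third result is a limit.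

Compound 4 `CC(=O)c1cccc(N2C(=O)CN(c3cccc(C(F)(F)F)c3)CC2C(=O)NC2CCCC2)c1` has not yet been measured. Its change from compound 3 is a group of 9 heavy atoms (8 carbon, 1 oxygen; one six-membered aromatic ring of carbon only) in place of a group of 8 heavy atoms (6 carbon, 1 nitrogen, 1 sulfur; one six-membered aromatic ring with 1 hetero atom), on an amide-type nitrogen in a ring and it places 3-acetylphenyl on an amide-type nitrogen in a ring, with the 3-(trifluoromethyl)phenyl group left as it is.

Going by the values given here, only one measured step alters the group at this same place, namely a 1.3-fold higher number from compound 1 to compound 3 (0.11 log units; within the scatter) and that exchange stayed inside the usual variation. The other measured step is an at least 2.5-fold higher number from compound 1 to compound 2 (0.39 log units; beyond the scatter) and concerns the trifluoromethyl group, which compound 4 keeps, so it does not carry over to this change.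

In this assay no step beyond the scatter is therefore expected, with a 1.0-fold lower number from compound 3 to compound 4 (0.02 log units; within the scatter) as the estimated step. The expected value for compound 4 is 25000 nM and the estimated range runs from 11000 nM to 50000 nM on this reasoning.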

Compound 4, half-maximal cytotoxic concentration: 40000 nM
For compound 4 the middle estimate is 1.6-fold (0.20 log units) below the measured one; the range from low to high includes it.
By their numbers in this assay, from the lowest: compounds 1, 3 and 4 (each within the scatter of the next). At a limit, above all of these: compound 2.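

In this assay, the place on the amide-type nitrogen in a ring now carries a third group, 3-acetylphenyl, and a 1.5-fold higher number from compound 3 to compound 4 (0.19 log units; within the scatter) stays inside the usual variation, as does a 2.0-fold higher number from compound 1 to compound 4 (0.30 log units; within the scatter). The earlier compounds had shown only an exchange of the aromatic ring at this place, with methylsulfanyl kept on it, whereas the new compound shows that putting acetyl in place of methylsulfanyl on an aromatic carbon also gives no step beyond the scatter. Across compound 1, compound 3 and compound 4, then, no exchange at this place separates one group from another in this assay, though three groups are a small sample.

Compound 2 gives only a limit, not a number, so how far it lies from the other three stays open: the limit of > 50000 nM in this assay, at which 1 of the 4 values shown sits.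

Also open, going by these compounds, is whether an amine or a carboxylic acid on this aromatic ring, or a chain longer than acetyl, would produce a step beyond the scatter, and whether 3-acetylphenyl would behave the same with methoxy in place of trifluoromethyl.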